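The source may hold more compounds than are shown below. What is called first, only, known or untested is meant among the compounds shown, and "the series" means these compounds.

Working notes on the aryl-urea series built on the shared core of compound 1.

Three compounds carry a value in an assay on isolated protein (Homo sapiens) for inhibition of HEXA/HEXB (Bos taurus), using a Dixon plot; a higher number here means a weaker inhibitor, a lower number a stronger inhibitor. Compound 1 `CC(=O)N[C@H]1/C(=N/NC(=O)Nc2ccc(C(F)(F)F)cc2)O[C@H](CO)[C@@H](O)[C@@H]1O` gives 125 nM in this assay. Compound 2 `CC(=O)N[C@H]1/C(=N/NC(=O)Nc2ccc3ccccc3c2)O[C@H](CO)[C@@H](O)[C@@H]1O` gives 47 nM in this assay. Compound 3 `CC(=O)N[C@H]1/C(=N/NC(=O)Nc2cccc3ccccc23)O[C@H](CO)[C@@H](O)[C@@H]1O` gives 154 nM in this assay. Compound 1 stands second highest of the three numbers; its nearest neighbour is compound 3, whose number lies within the scatter of compound 1, and its furthest is compound 2, whose number lies beyond the scatter on the lower side. No pair of these compounds differs in one place only, so no single step between measured compounds is available.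

Compound 4 `COc1ccc(NC(=O)N/N=C2\O[C@H](CO)[C@@H](O)[C@H](O)[C@H]2NC(C)=O)cc1` is not yet measured in this assay. It differs from compound 1 as follows: methoxy in place of trifluoromethyl on an aromatic carbon. Going by the values given here, with no comparable step recorded, the expectation for this exchange is a small move, if any, beyond the scatter, in the direction of a weaker inhibitor. Compound 4 is therefore expected at about 160 nM in this assay, within a range of 60 nM to 420 nM, a step of a 1.3-fold higher number from compound 1 to compound 4 (0.11 log units; within the scatter) that is estimated rather than known.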

Compound 4, inhibition constant: 413 nM
Beside the measured number, compound 4's estimate is 2.6-fold (0.41 log units) below it; measured number inside the range.
By their numbers in this assay, from the lowest: compound 2; then compounds 1 and 3 (each within the scatter of the next); then compound 4.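

Methoxy in place of trifluoromethyl on this aromatic carbon gives the series its first single-place comparison in this assay: a 3.3-fold higher number from compound 1 to compound 4 (0.52 log units; beyond the scatter), a move toward a weaker inhibitor, so the group at this position, para to a large group, can shift the number beyond the scatter. Compounds 2 and 3 differ from compound 1 in more than one place, so they offered no such reading of this position. Nothing shown here accounts for the size or direction of this step.

A single exchange cannot show whether another group on this carbon, such as a nitrile or a chlorine atom, would stay close to compound 1 or move further from it. It also leaves open whether the same exchange would read alike with a different aryl group on the urea.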